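This account rests on a few compounds, and the source may have more. Where it says the series, first, only, none or still open, it means among the compounds named here.

In an ADME assay on HepG2 cells (Homo sapiens) for cytotoxicity (on this read-out lower numbers stand for higher toxicity in this test and higher numbers for lower toxicity in this test), compound 3 `Cc1ncn(C)c1C(=O)N[C@H](/C=C/S(=O)(=O)c1ccccc1)CCc1ccccc1` gives 34400 nM and compound 1 `O=C(N[C@H](/C=C/S(=O)(=O)c1ccccc1)CCc1ccccc1)c1cccc2nccnc12` gives 39600 nM, two numbers within the scatter of each other. Compound 2 `CC1=CC(C)(C)Nc2c(C(=O)N[C@H](/C=C/S(=O)(=O)c3ccccc3)CCc3ccccc3)cccc21` returns only a limit, > 300000 nM. Compound 4 `Cn1cc([N+](=O)[O-])nc1C(=O)N[C@H](/C=C/S(=O)(=O)c1ccccc1)CCc1ccccc1` carries 1-methyl-4-nitro-1H-imidazol-2-yl in place of 1,4-dimethyl-1H-imidazol-5-yl on a carbonyl carbon. The closest measured precedent is a 1.2-fold lower number from compound 1 to compound 3 (0.06 log units; within the scatter), where 1,4-dimethyl-1H-imidazol-5-yl replaces quinoxalin-5-yl at that same place. This single exchange offers no basis for a large shift, so no step beyond the scatter is expected in this assay. The expected step is a 1.2-fold higher number from compound 3 to compound 4 (0.07 log units; within the scatter). Compound 4 is estimated at 40000 nM, with an expected range of 13000 nM to 130000 nM.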

Compound 4, half-maximal cytotoxic concentration: 28800 nM
Compound 4: middle estimate off by 1.4-fold (0.14 log units), on the high side; low and high end bracket the measured number.
By their numbers in this assay, from the lowest: compounds 4, 3 and 1 (each within the scatter of the next). At a limit, above all of these: compound 2.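

In this assay, 1-methyl-4-nitro-1H-imidazol-2-yl is taken up on the carbonyl carbon with no step beyond the scatter (a 1.2-fold lower number from compound 3 to compound 4 (0.08 log units; within the scatter)). The comparison with quinoxalin-5-yl also stays within the scatter (a 1.4-fold lower number from compound 1 to compound 4 (0.14 log units; within the scatter)). A nitro-bearing five-membered ring therefore joins the two earlier groups, and compounds 1, 3 and 4 all lie within the scatter of one another.

Compound 2 gives only a limit (> 300000 nM), so its distance from the others stays unresolved. Going by these compounds, whether an amine or a carboxylic acid on the group at this place would also stay within the scatter remains open.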